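Amino substitution on the phenyl ring of compound 1

The source may report more compounds than this note shows. Statements on the series, on what has been measured and on what is new or still open speak of the compounds shown alone.

Among the compounds with values here, compound 1 `Oc1ccc(C2CC(c3ccccc3)=NN2c2ccc(Cl)cc2)cc1` stands highest of the two numbers so far in an assay on isolated protein for inhibition of protein kinase C zeta type (Homo sapiens), with a stated time of 4 min, tested at 62.5 uM; a lower number here means less inhibition, a higher number more inhibition at the concentration tested (going by the name of the read-out): compound 1 gives 95.6%. Its nearest neighbour is compound 2 `Oc1ccc(C2CC(c3ccccc3)=NN2c2cccc(Cl)c2)cc1`, which in this assay gives 90.5%; the step of a number 5.1 percentage points lower from compound 1 to compound 2 (within the scatter) lies within the scatter, so the two stand level.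

Compound 3 `Nc1ccc(C2=NN(c3ccc(Cl)cc3)C(c3ccc(O)cc3)C2)cc1` is not yet measured. It differs from compound 1 by amino in place of hydrogen on an aromatic carbon.

Within the data shown here, only one measured step exists, that from compound 1 to compound 2, and it concerns the chlorophenyl on the amine nitrogen in the ring, not the phenyl that receives the amino group. It bears on the present change only in showing that one change at an aromatic ring left the read-out within the scatter. Among the measured compounds shown here, no measured step addresses an amino group. With compound 1 near the top of the scale, little room remains upward, so the expected step of a number 5.6 percentage points lower from compound 1 to compound 3 (within the scatter) in this assay is small, with no direction beyond the scatter. Compound 3 is therefore estimated at 90% in this assay, within 72% to 99%.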

Compound 3, a percentage reported as inhibition, at one concentration (the size of the read-out at that concentration, not a potency): 98%
Compound 3: middle estimate off by 8 percentage points, on the low side; the range from low to high includes it.
By their numbers in this assay, from the lowest: compounds 2, 1 and 3 (each within the scatter of the next).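

In this assay, the exchange of phenyl to 4-aminophenyl gives a number 2.4 percentage points higher from compound 1 to compound 3 (within the scatter), so compound 1 and compound 3 stand level. Within the data shown here, this is the first measured change on this phenyl ring, where the earlier step concerned only the chlorophenyl on the amine nitrogen in the ring, and it shows that an amino group on this aromatic carbon, para to a large group, leaves the read-out within the scatter and near the top of the scale. No measurement available here gives an explanation for this outcome.

Going by these compounds, whether the level result extends to other groups at this place stays open, for instance a carboxylic acid, a methoxy group or an acetamide, any of which would show whether this position accepts more than a single amino group. On these data alone, the read-out is taken at one concentration and is not a potency, so any difference in potency between compound 1 and compound 3 remains open while both numbers lie this close to the top of the scale.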